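Ethoxycarbonyl for bromo on the sulfonamide series

The compounds below may be only part of what the source reports. "The series", "measured", "known", "first", "only" and "open" are said of these compounds alone.

Measured in a functional assay on HL-60 cells (Homo sapiens) for cytotoxicity, read by MTT assay; a higher number here means a weaker inhibitor, a lower number a stronger inhibitor:
- compound 1 `CCOC(=O)c1ccc(S(=O)(=O)NC(C2=CC(=O)c3c(O)ccc(O)c3C2=O)C(C)C)cc1`: 150 nM
- compound 2 `CC(NS(=O)(=O)c1ccc(F)cc1)C1=CC(=O)c2c(O)ccc(O)c2C1=O`: 90 nM
- compound 3 `CC(NS(=O)(=O)c1ccc(Br)cc1)C1=CC(=O)c2c(O)ccc(O)c2C1=O`: 100 nM

Compound 3 at 100 nM lies within the scatter of both other compounds. Compound 4 `CCOC(=O)c1ccc(S(=O)(=O)NC(C)C2=CC(=O)c3c(O)ccc(O)c3C2=O)cc1`, not yet measured, has ethoxycarbonyl in place of bromo on an aromatic carbon, para to a large group (ethoxycarbonyl in place of bromo on an aromatic carbon). Within the data shown here, the only measured step at this place, a 1.1-fold higher number from compound 2 to compound 3 (0.05 log units; within the scatter), exchanges fluoro for bromo and does not test ethoxycarbonyl. Compound 1 carries ethoxycarbonyl but differs elsewhere, and it gives 150 nM. No step beyond the scatter is therefore expected in this assay. The estimated move is a 1.2-fold higher number from compound 3 to compound 4 (0.08 log units; within the scatter). Compound 4 is expected at 120 nM, with an estimated range of 60 nM to 240 nM.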

Compound 4, half-maximal inhibitory concentration: 120 nM
The estimate for compound 4 equals the measured number at the digits printed; measured number inside the range.
By their numbers in this assay, from the lowest: compounds 2, 3, 4 and 1 (each within the scatter of the next).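

In this assay, the aromatic carbon para to a large group accepts ethoxycarbonyl, with five heavy atoms in place of one, as a 1.2-fold higher number from compound 3 to compound 4 (0.08 log units; within the scatter) and a 1.3-fold higher number from compound 2 to compound 4 (0.12 log units; within the scatter) show for the exchanges of bromo and fluoro. With ethoxycarbonyl held fixed, methyl in place of isopropyl on the saturated chain carbon gives a 1.3-fold lower number from compound 1 to compound 4 (0.10 log units; within the scatter) and thus no separation at that place either. Nothing measured here accounts for these small steps.

Going by these compounds, whether an amine or a carboxylic acid on the same aromatic carbon would give a step beyond the scatter remains open. On these data alone, a longer chain in place of ethoxycarbonyl also remains untested in these compounds.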